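The compounds below may be only part of what the source reports. "The series", "measured", "known", "first", "only" and "open" are said of these compounds alone.

Series notes

- compound 1 `CC(=O)Nc1ccc(S(=O)(=O)Oc2ccccc2I)cc1` — 23000 nM
- compound 2 `CCC(=O)Nc1ccc(S(=O)(=O)Oc2ccccc2I)cc1` — 11000 nM
- compound 3 `CCCCCC(=O)Nc1ccc(S(=O)(=O)Oc2ccccc2C(C)C)cc1` — 6400 nM

Within the data shown here, in a functional assay on HT-29 cells (Homo sapiens) for antiproliferative activity, read by sulforhodamine B assay, with a stated time of 48 h (on this read-out higher numbers stand for weaker inhibition and lower numbers for stronger inhibition), compound 1 gives 23000 nM and compound 2 gives 11000 nM; the step of a 2.1-fold lower number from compound 1 to compound 2 (0.32 log units; beyond the scatter) is the only single-point change measured so far. Compound 3, with the hexanoyl amide and the isopropyl group, gives 6400 nM. Against the numbers shown, compound 3 sits within the scatter of compound 2 and beyond the scatter below compound 1.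

Compound 4 `CCCCCC(=O)Nc1ccc(S(=O)(=O)Oc2ccccc2I)cc1` differs from compound 3 in one place: iodo in place of isopropyl on an aromatic carbon. Among the measured compounds shown here, no measured step bears on this exchange; the two iodo compounds carry shorter amide chains than compound 3, so the chain and the aryl substituent are changed together in every comparison across the set. The measured step of a 2.1-fold lower number from compound 1 to compound 2 (0.32 log units; beyond the scatter) concerns the chain, not the aryl group, and gives no direct guide here.

The expectation for compound 4 is therefore a step of a 1.3-fold higher number from compound 3 to compound 4 (0.10 log units; within the scatter) no larger than the scatter, with wide uncertainty, and an estimated value of 8000 nM in this assay, between 3000 nM and 22000 nM.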

Compound 4, half-maximal inhibitory concentration: 13000 nM
Compound 4: the middle estimate sits 1.6-fold (0.21 log units) below what was measured; low and high end bracket the measured number.
By their numbers in this assay, from the lowest: compounds 3, 2, 4 and 1 (each within the scatter of the next, the first and the last beyond it).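

In this assay the exchange on the aromatic carbon now has a direct reading: with the hexanoyl amide held fixed, iodo in place of isopropyl gives a 2.0-fold higher number from compound 3 to compound 4 (0.31 log units; beyond the scatter), so the aryl substituent alone produces a modest step. With iodo held fixed, the two chain steps, a 1.2-fold higher number from compound 2 to compound 4 (0.07 log units; within the scatter) and a 1.8-fold lower number from compound 1 to compound 4 (0.25 log units; within the scatter), both lie within the scatter, so the step beyond the scatter seen between the acetyl and propanoyl amides does not extend into a trend with chain length across the iodo compounds. No supporting evidence accounts for either the aryl step or the flat chain steps.

Going by these compounds, whether the exchange of isopropyl for iodo keeps its size on the acetyl or propanoyl amide remains open. Also open, on these data alone, is how an octanoyl chain, or an amine or carboxylic acid at the end of the amide chain, would read here.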